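The source may report more compounds than this note shows. Statements on the series, on what has been measured and on what is new or still open speak of the compounds shown alone.

Measured so far in a functional assay on SW480 cells (Homo sapiens) for cytotoxicity, read by MTT assay, with a stated time of 4 days; a lower number here means a stronger inhibitor, a higher number a weaker inhibitor:

Compound 1 `C=C1C(=O)[C@]23C[C@@]1(O)CC[C@H]2c1ccc(OS(=O)(=O)c2ccc(C)cc2)c(C)c1[C@@H]3Cn1cc(-c2ccccn2)nn1`: 1970 nM
Compound 2 `C=C1C(=O)[C@]23C[C@@]1(O)CC[C@H]2c1ccc(OS(=O)(=O)c2ccc(C)cc2)c(C)c1[C@@H]3Cn1cc(-c2ccc(Br)cc2)nn1`: 1590 nM
Compound 3 `C=C1C[C@]23C[C@@]1(O)CC[C@@H]2c1cccc(C)c1[C@@H]3Cn1cc(-c2ccc(Br)cc2)nn1`: in this assay compound 3 gives only a limit, > 20000 nM.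

Compound 2 and compound 1 share one core and differ only in the group on the triazole: pyridin-2-yl in place of 4-bromophenyl on an aromatic carbon. The step is a 1.2-fold higher number from compound 2 to compound 1 (0.09 log units; within the scatter), so on this core the two groups read as equivalent.

Compound 3 carries a different core; the difference between the two cores is not broken down here. Compound 3 sits at the limit described by the limit of > 20000 nM in this assay, at which 1 of the 3 values shown sits, so its value is a limit of the assay, not a number.

Compound 4 `C=C1C[C@]23C[C@@]1(O)CC[C@@H]2c1cccc(C)c1[C@@H]3Cn1cc(-c2ccccn2)nn1` is compound 3 with the same change applied: pyridin-2-yl in place of 4-bromophenyl on an aromatic carbon. The place lines of both changes agree word for word, so it is the same change, now made on the core of compound 3.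

Within the data shown here, the expected step from compound 3 to compound 4 is a step that the limit leaves unreadable from compound 3 to compound 4, since the only measured instance of this change gave a 1.2-fold higher number from compound 2 to compound 1 (0.09 log units; within the scatter). Because compound 3 reports only > 20000 nM, compound 4 is also expected to reach the limit rather than a number. Compound 4 is estimated at 30000 nM, with a range from 12000 nM to 80000 nM.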

Compound 4, half-maximal inhibitory concentration: > 20000 nM
Compound 4 ended at the assay's limit; the forecaster's own chance of this, stated with the estimate: 75%; the middle value is on the limit's open side.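

In this assay compound 4 gives > 20000 nM, a limit of the assay and not a number. Compound 3 also reports only a limit, so no step from compound 3 to compound 4 can be read: the limit of > 20000 nM in this assay, at which 2 of the 4 values shown sit.

The compounds shown leave open whether pyridin-2-yl in place of 4-bromophenyl changes anything on the core of compound 3.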